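The compounds below may be only part of what the source reports. "The series", "measured", "known", "first", "only" and "open" are said of these compounds alone.

The measured compounds, each in an ADME assay on HCT-116 cells (Homo sapiens) for cytotoxicity, read by MTT assay, with a stated time of 72 h; on this read-out higher numbers stand for weaker inhibition and lower numbers for stronger inhibition:

Compound 1, `Cc1ccc(NC(=O)c2cccc(/C=C3\CC(=O)N(c4ccccc4)C3=O)c2)cc1C`, gives a value that is a limit of the assay, > 100000 nM.
Compound 2, `CCc1cccc(NC(=O)c2cccc(/C=C3\CC(=O)N(c4ccccc4)C3=O)c2)c1`, gives 81200 nM.
Compound 3, `COc1ccc(OC)c(NC(=O)c2cccc(/C=C3\CC(=O)N(c4ccccc4)C3=O)c2)c1`, gives a value that is again a limit of the assay, > 100000 nM.

For the measured compounds named here, compound 3 therefore stands at the upper edge of what this assay reports; no number is known for it, only that its value lies beyond the cut-off, and it shares this position with compound 1 (the limit of > 100000 nM in this assay, at which 2 of the 3 values shown sit). Compound 4, `Cc1cccc(NC(=O)c2cccc(/C=C3\CC(=O)N(c4ccccc4)C3=O)c2)c1`, has not yet been measured. It differs from compound 3 in one place: 3-methylphenyl in place of 2,5-dimethoxyphenyl on an amide-type nitrogen.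

Going by the values given here, two measured steps bear on this change. Going the other way, from an alkyl-bearing phenyl to the dimethoxyphenyl, gave an at least 1.2-fold higher number from compound 2 to compound 3 (0.09 log units; that floor lies within the scatter). The step that the two limits leave unreadable from compound 1 to compound 3 cannot be read, since both ends are limits. The step of an at least 1.2-fold lower number from compound 1 to compound 2 (0.09 log units; that floor lies within the scatter) is small and within the scatter. Nothing here points to a change larger than the scatter in either direction, so for compound 4 only a small step toward a lower number is expected, an at least 1.1-fold lower number from compound 3 to compound 4 (0.04 log units; that floor lies within the scatter), with a real chance that the assay again reports only a limit. Compound 4 is thus estimated at 90000 nM, between 40000 nM and 250000 nM.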

Compound 4, half-maximal inhibitory concentration: > 100000 nM
Compound 4 ended at the assay's limit; the forecaster's own chance of this, stated with the estimate: 50%; at least 1.1-fold (0.04 log units) between middle value and limit.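

In this assay compound 4 gives > 100000 nM, which is a limit of the assay and not a number. Both ends are limits for the steps to compound 4 from compound 3 and from compound 1, so neither step can be read; the only readable one, an at least 1.2-fold higher number from compound 2 to compound 4 (0.09 log units; that floor lies within the scatter), shows that replacing the methyl at the end of the ethyl group with hydrogen opens no gap beyond the scatter. What the new result adds is that a 3-methylphenyl on the amide-type nitrogen, carrying no oxygen, ends at the same limit as the 2,5-dimethoxyphenyl, and that most of this small set now sits at the edge of what the assay can report: the limit of > 100000 nM in this assay, at which 3 of the 4 values shown sit.

Going by these compounds, how far compound 1, compound 3 and compound 4 lie beyond that limit remains unknown, so these three cannot be ranked against one another. Also open, on these data alone, is whether a phenyl carrying an amine or a carboxylic acid on the same amide-type nitrogen would give a readable number, clearly lower than the limit.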